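The compounds below may be only part of what the source reports. "The series", "measured", "known", "first", "only" and "open" are said of these compounds alone.

Working notes on the series. Compound 1 `O=C(Nc1cc(-c2ccccc2)nn1-c1ccccc1Br)c1ccccc1` is the unsubstituted benzamide; in an assay on HEK293 cells for displacement of a labelled ligand from metabotropic glutamate receptor 5 (Rattus norvegicus) (a higher number here means a weaker inhibitor, a lower number a stronger inhibitor), compound 1 gives 2600 nM. Compound 2 `O=C(Nc1cc(-c2ccccc2)nn1-c1ccccc1Br)c1cccc([N+](=O)[O-])c1` differs from compound 1 only by nitro in place of hydrogen on an aromatic carbon, and in this assay compound 2 gives 230 nM. The step made by that change is an 11-fold lower number from compound 1 to compound 2 (1.05 log units; beyond the scatter).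

Compound 3 `O=C(Nc1c(-c2ccccc2)cnn1-c1ccccc1)c1ccccc1` is built on a second core; the difference between the two cores is not broken down here. In this assay compound 3 gives 1170 nM, which places compound 3 second highest of the three numbers, beyond the scatter from compound 1 and from compound 2.

Compound 4 `O=C(Nc1c(-c2ccccc2)cnn1-c1ccccc1)c1ccc([N+](=O)[O-])cc1` is the unmeasured member. It differs from compound 3 by nitro in place of hydrogen on an aromatic carbon. Among the compounds shown this change occurs two times. It is the same kind of change as that from compound 1 to compound 2, not the same: in compound 2 the entering group stands meta to a large group, in compound 4 para to a large group.

The expected step is a 5.3-fold lower number from compound 3 to compound 4 (0.73 log units; beyond the scatter), set beside an 11-fold lower number from compound 1 to compound 2 (1.05 log units; beyond the scatter), on which the expectation rests. The expected step is taken smaller than that earlier one, since the entering group stands at a different place and the core is not the same, so a full transfer of the step cannot be assumed.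

In this assay compound 4 is expected to give 220 nM, within a range from 70 nM to 700 nM.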

Compound 4, inhibition constant: > 10000 nM
Compound 4 gave a limit, no number; the forecaster's own chance of this, stated with the estimate: 3%; middle value at least 45-fold (1.65 log units) from the limit.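

In this assay compound 4 gives > 10000 nM and this is a limit of the assay and not a number. The step of an at least 8.5-fold higher number from compound 3 to compound 4 (0.93 log units; beyond the scatter) runs opposite to the earlier step, so nitro in place of hydrogen on an aromatic carbon cannot be carried from the core of compound 1 to the core of compound 3 in this series, even in direction: the same change on two cores in this assay, an 11-fold lower number (1.05 log units; beyond the scatter) from compound 1 to compound 2 and an at least 8.5-fold higher number (0.93 log units; beyond the scatter) from compound 3 to compound 4, at least 96-fold (1.98 log units) apart, beyond the scatter of two such steps
What this does not show is which difference separates the two steps, since the entering group changes place as well as core, or how large the new step really is, as only its lower bound can be read: the limit of > 10000 nM in this assay, at which 1 of the 4 values shown sits.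

No pair shown keeps one core and moves the nitro group, so the effect of place on either core remains open, as does whether compound 4 reflects the change from phenyl to 4-nitrophenyl in general or only this particular place on this core. Also open, as far as these compounds go, is how other groups at that place on the core of compound 3 would read in this assay, for instance a nitrile, an amine or a carboxylic acid in place of the nitro group.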